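A few compounds are considered here, and "the series" means these few. Any claim that something is new, unique, unknown or untested is made for them only; others in the source may bear on it.

Compound 2, `Cc1csc2cc([C@H](C)Nc3ncnc(N)c3C#N)c(Cc3cccc(CN(C)CC(C)C)c3)c(=O)n12`, is examined in an ADME assay on the whole organism (lung, Rattus norvegicus) for metabolic stability, read by LC-MS (on this read-out higher numbers stand for a longer-lived compound and lower numbers for a shorter-lived compound), where compound 2 gives 2.3 h. For the measured compounds named here, that is the lower of the two numbers known so far. The other belongs to compound 1, `Cc1csc2cc([C@H](C)Nc3ncnc(N)c3C#N)c(-c3cccc(CN4CCC(N(C)CCC(F)(F)F)CC4)c3)c(=O)n12`, and in this assay compound 1 gives 8.7 h, a number that stands higher than that of compound 2 by more than the usual scatter. The two compounds differ in several places at once, so their gap cannot be tied to any single change.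

Compound 3, `CNCc1cccc(Cc2c([C@H](C)Nc3ncnc(N)c3C#N)cc3scc(C)n3c2=O)c1`, has not yet been measured. It differs from compound 2 in one place: hydrogen in place of isobutyl on an amine nitrogen. Going by the values given here, no pair of measured compounds shows this change, so there is no step to rest an expectation on. Compound 3 is therefore expected to stay close to compound 2, with the step of a 1.3-fold higher number from compound 2 to compound 3 (0.12 log units; within the scatter) expected to fall within the scatter. Compound 3 is estimated at 3 h, between 1.4 h and 6.5 h.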

Compound 3, half-life in the lung assay: 4.9 h
Compound 3: the middle estimate sits 1.6-fold (0.21 log units) below what was measured, and the stated range covers the measured number.
By their numbers in the lung assay, from the lowest: compound 2; then compounds 3 and 1 (each within the scatter of the next).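

In the lung assay, this change now has a reading of its own: hydrogen in place of isobutyl on the amine nitrogen gives a 2.1-fold higher number from compound 2 to compound 3 (0.33 log units; beyond the scatter), a modest step. In a physicochemical assay for lipophilicity (a lower number here means a more polar compound, a higher number a more lipophilic compound), compound 2 gives 2.3 and compound 3 gives -0.2, so the same change also moves this second read-out. At this position, the longer half-life therefore comes with a compound that is much less lipophilic, although a single pair links the two only by coincidence of direction: the measured distribution coefficient of compound 2, 2.3, and of compound 3, -0.2, a number 2.50 log units lower (beyond the scatter)

As far as these compounds go, whether the half-life follows lipophilicity in general, or depends on the isobutyl group itself, remains open. An ethyl group or a hydroxyethyl chain on the same nitrogen would help separate the two in the lung assay.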